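This account rests on a few compounds, and the source may have more. Where it says the series, first, only, none or still open, it means among the compounds named here.

In a functional assay on KYSE-70 cells for antiproliferative activity against KYSE-70 cell line (Homo sapiens), read by MTT assay, with a stated time of 72 h (a higher number here means a weaker inhibitor, a lower number a stronger inhibitor), compound 3 `O=C(Nc1cccc(F)c1)c1cc(=O)[nH]c2cc(-c3ccc(F)nc3)ccc12` gives > 20000 nM, a limit of the assay and not a number. Compound 1 `COc1ccc(-c2ccc3c(C(=O)Nc4cccc(F)c4)cc(=O)[nH]c3c2)cc1` gives > 20000 nM, likewise a limit. Going by the values given here, compound 2 `O=C(Nc1cccc(F)c1)c1cc(=O)[nH]c2cc(-c3cccc(F)c3)ccc12` gives 12000 nM, the only actual number so far. Compound 4 `C=Cc1ccc2c(C(=O)Nc3cccc(F)c3)cc(=O)[nH]c2c1` carries vinyl in place of 6-fluoropyridin-3-yl on an aromatic carbon. Exchanges of the group on that carbon gave an at least 1.6-fold lower number from compound 1 to compound 2 (0.22 log units; that floor lies within the scatter) and an at least 1.6-fold higher number from compound 2 to compound 3 (0.22 log units; that floor lies within the scatter), while the remaining exchange gave a step that the two limits leave unreadable from compound 1 to compound 3. None of these exchanges brings in a group without a ring. The expectation therefore leans on (the limit of > 20000 nM in this assay, at which 2 of the 3 values shown sit), and no step beyond the scatter is expected. The expected step is a number no higher from compound 3 to compound 4 (the limit leaves the size open). For compound 4 the estimate is 20000 nM, with an expected range of 7000 nM to 40000 nM.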

Compound 4, half-maximal inhibitory concentration: 9700 nM
Compound 4: middle estimate off by 2.1-fold (0.31 log units), on the high side; the range from low to high includes it.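

In this assay, an aryl ring on this aromatic carbon proves dispensable: vinyl, a group with no ring, gives an at least 2.0-fold lower number from compound 3 to compound 4 (0.31 log units; beyond the scatter) and an at least 2.0-fold lower number from compound 1 to compound 4 (0.31 log units; beyond the scatter). Against the 3-fluorophenyl group, vinyl gives a 1.2-fold lower number from compound 2 to compound 4 (0.09 log units; within the scatter), so the two groups are not separated. The two larger steps are floors only, since compound 1 and compound 3 each stand at a limit of the assay: the limit of > 20000 nM in this assay, at which 2 of the 4 values shown sit.

From the compounds shown here alone, whether an ethyl group, a longer chain or an amine on this carbon would shift the number beyond the scatter stays open.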